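Replacing 4-methylphenyl with 3-(diethylamino)propyl on an amide nitrogen

The source may report more compounds than this note shows. Statements on the series, on what has been measured and on what is new or still open speak of the compounds shown alone.

Compound 1 `O=C(CCC(=O)OCCCCCCSc1ccc([N+](=O)[O-])c2nonc12)Nc1ccc(F)cc1`: 2080 nM
Compound 2 `Cc1ccc(NC(=O)CCC(=O)OCCCCCCSc2ccc([N+](=O)[O-])c3nonc23)cc1`: 3340 nM

Among the compounds with values here, in a functional assay on HOS cells (Homo sapiens) for inhibition, read by MTT assay, with a stated time of 72 h (a lower number here means a stronger inhibitor, a higher number a weaker inhibitor), compound 2 gives 3340 nM, which lies within the scatter of the only other measured value. Compound 3 `CCN(CC)CCCNC(=O)CCC(=O)OCCCCCCSc1ccc([N+](=O)[O-])c2nonc12`, not yet measured, carries 3-(diethylamino)propyl in place of 4-methylphenyl on an amide-type nitrogen.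

Within the data shown here, only one measured step is available, a 1.6-fold higher number from compound 1 to compound 2 (0.21 log units; within the scatter). It is methyl in place of fluoro on an aromatic carbon, so it bears only weakly on a change that removes the whole 4-methylphenyl group. Among the measured compounds shown here, no measured step shows what such a replacement does. No step beyond the scatter can therefore be expected in this assay, in either direction, though a real shift cannot be ruled out. The expected step is a 1.3-fold lower number from compound 2 to compound 3 (0.13 log units; within the scatter). For compound 3 the estimate is 2500 nM, with an expected range of 600 nM to 10000 nM.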

Compound 3, half-maximal inhibitory concentration: 9060 nM
The estimate for compound 3 lay 3.6-fold (0.56 log units) below the measured number; low and high end bracket the measured number.
By their numbers in this assay, from the lowest: compounds 1 and 2 (each within the scatter of the next); then compound 3.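

In this assay, within the data shown here, this is the first change at the amide-type nitrogen to move the number beyond the scatter: 3-(diethylamino)propyl in place of 4-methylphenyl gives a 2.7-fold higher number from compound 2 to compound 3 (0.43 log units; beyond the scatter), and in place of 4-fluorophenyl it gives a 4.4-fold higher number from compound 1 to compound 3 (0.64 log units; beyond the scatter). Both steps are modest and run the same way, so at this position the ringless chain gives a weaker inhibitor than either of the two substituted phenyl groups. Nothing measured here says why the number rises.

The compounds shown leave open whether the step follows from losing the aromatic ring or from gaining the amine, as the two change together in compound 3. A plain alkyl chain without the amine, or a phenyl ring carrying a diethylamino group, would separate these two changes.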